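Replacing the Fluoro Group of Compound 2 with Hydrogen

The compounds below may be only part of what the source reports. "The series", "measured", "known", "first", "only" and "open" are said of these compounds alone.

Of the compounds shown here, two sharing one core have been measured in a functional assay on MM1.S cells (Homo sapiens) for cytotoxicity, read by MTT assay, with a stated time of 48 h (a higher number here means a weaker inhibitor, a lower number a stronger inhibitor), so far. There, compound 1 (`FC(F)(F)c1cccc(NN=C2C(Cl)=C(Cl)C(Cl)=C2Cl)c1`) gives 1000 nM as its half-maximal inhibitory concentration. Compound 2 (`Fc1ccc(NN=C2C(Cl)=C(Cl)C(Cl)=C2Cl)cc1`) gives 1300 nM and so stands within the usual scatter of compound 1, which means that the two numbers set no order between them.

Compound 3 (`ClC1=C(Cl)C(Cl)=C(Cl)C1=NNc1ccccc1`) has yet to be measured. It departs from compound 2 by a single change (hydrogen in place of fluoro on an aromatic carbon): hydrogen in place of fluoro on an aromatic carbon, para to a large group. Going by the values given here, no measured pair of compounds isolates this change, so the data offer no direct guide to its size. The expectation rests only on compound 2 at 1300 nM as the starting point, and no shift beyond the scatter is expected in this assay for this replacement. The estimated step is a 1.2-fold higher number from compound 2 to compound 3 (0.06 log units; within the scatter) and is expected to remain within the scatter. Compound 3 is estimated at 1500 nM with an expected range of 700 nM to 3300 nM as the likely span.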

Compound 3, half-maximal inhibitory concentration: 2000 nM
Compound 3: middle estimate off by 1.3-fold (0.12 log units), on the low side; measured number inside the range.
By their numbers in this assay, from the lowest: compounds 1, 2 and 3 (each within the scatter of the next).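

In this assay, hydrogen in place of fluoro on an aromatic carbon, para to a large group, gives a 1.5-fold higher number from compound 2 to compound 3 (0.19 log units; within the scatter), so this first direct test of the change shows that the fluoro group can be replaced by hydrogen without a step beyond the scatter. Hydrogen in place of trifluoromethyl on an aromatic carbon gives a 2.0-fold higher number from compound 1 to compound 3 (0.30 log units; within the scatter), so in this small set neither the fluoro group nor the trifluoromethyl group can be told apart from hydrogen in this assay. No measurement is available here that would explain these numbers.

The compounds shown leave open whether a different group on this aromatic carbon, such as an amine, a carboxylic acid or a methoxy group, would produce a step beyond the scatter. They also leave open what the chloro groups on the shared core contribute, as all three compounds carry them unchanged and no comparison here isolates them.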